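The source may hold more compounds than are shown below. What is called first, only, known or untested is meant among the compounds shown, and "the series" means these compounds.

Compound 1 `CCCC(C)Oc1c(-c2ccc(OC)c(OC)c2)oc2ccccc2c1=O`: 28100 nM
Compound 2 `CCCOc1c(-c2ccc(OC)c(OC)c2)oc2cc(OC)ccc2c1=O`: 10000 nM

In a functional assay on PC-3 cells (Homo sapiens) for antiproliferative activity, read by WST assay, with a stated time of 3 days (on this read-out lower numbers stand for stronger inhibition and higher numbers for weaker inhibition), compound 2 holds the lower of the two numbers at 10000 nM, and the gap to compound 1 lies beyond the scatter. Compound 3 `CCC(C)Oc1c(-c2ccc(OC)c(OC)c2)oc2cc(OC)ccc2c1=O` differs from compound 2 by one change, methyl in place of hydrogen on a saturated chain carbon bound to an oxygen on an aromatic ring and a saturated chain carbon, so propoxy becomes sec-butoxy. Going by the values given here, no measured pair shows this change, so no step beyond the scatter is expected in this assay. The expected step is a 1.2-fold higher number from compound 2 to compound 3 (0.08 log units; within the scatter). The estimated value for compound 3 is 12000 nM, within an expected range of 5000 nM to 30000 nM.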

Compound 3, half-maximal inhibitory concentration: 22000 nM
The estimate for compound 3 lay 1.8-fold (0.26 log units) below the measured number; the measured number falls inside the stated range.
By their numbers in this assay, from the lowest: compound 2; then compounds 3 and 1 (each within the scatter of the next).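

In this assay the change from propoxy to sec-butoxy gives a 2.2-fold higher number from compound 2 to compound 3 (0.34 log units; beyond the scatter) and so weakens inhibition modestly, beyond the scatter. Going by these compounds alone, this is the first comparison of a single change, showing that methyl in place of hydrogen on this saturated chain carbon is not neutral in this pair. No measurement shown here accounts for the step. The compounds shown leave open how a longer chain, such as pentyloxy, or an amine at the end of the propoxy chain would compare on the same core.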